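Swapping 4-chlorophenyl for 3-nitrophenyl in a cytotoxicity series

A few compounds are considered here, and "the series" means these few. Any claim that something is new, unique, unknown or untested is made for them only; others in the source may bear on it.

The shared core of this series is compound 1 `CC(C)=CCC/C(C)=C/CC/C(C)=C/CC[C@@H]1[C@@]2(C)CCC(=O)C(C)(C)[C@@H]2CC[C@@]1(C)O`. In a functional assay on HeLa cells (Homo sapiens) for cytotoxicity, read by MTT assay, with a stated time of 48 h (a lower number here means a stronger inhibitor, a higher number a weaker inhibitor), compound 1 gives 18300 nM. Compound 2 `CC(C)=CCC/C(C)=C/CC/C(C)=C/CC[C@@H]1[C@@]2(C)CC/C(=N\OCc3cn(-c4ccccc4)nn3)C(C)(C)[C@@H]2CC[C@@]1(C)O` carries a phenyl group on the five-membered aromatic ring with 3 nitrogen, and in this assay compound 2 gives 7760 nM. Compound 3 `CC(C)=CCC/C(C)=C/CC/C(C)=C/CC[C@@H]1[C@@]2(C)CC/C(=N\OCc3cn(-c4ccc(Cl)cc4)nn3)C(C)(C)[C@@H]2CC[C@@]1(C)O` differs from compound 2 by a chloro in place of hydrogen on an aromatic carbon, and in this assay compound 3 gives 14800 nM. That one measured step was a 1.9-fold higher number from compound 2 to compound 3 (0.28 log units; within the scatter). Compound 3 therefore sits among three numbers that all lie within the scatter of one another: its gap to compound 1 and its gap to compound 2 are both too small to count as a real difference.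

Compound 4 `CC(C)=CCC/C(C)=C/CC/C(C)=C/CC[C@@H]1[C@@]2(C)CC/C(=N\OCc3cn(-c4cccc([N+](=O)[O-])c4)nn3)C(C)(C)[C@@H]2CC[C@@]1(C)O` is the next variation. It differs from compound 3 as follows: 3-nitrophenyl in place of 4-chlorophenyl on an aromatic nitrogen. For the measured compounds named here, the only measured step that bears on changing this aromatic ring, from compound 2 to compound 3, stayed within the scatter, and no measured step involves a nitro group at all. The expected step of a 1.2-fold lower number from compound 3 to compound 4 (0.09 log units; within the scatter) in this assay is therefore small, in no clear direction. Compound 4 is estimated at 12000 nM, with a range from 5000 nM to 30000 nM.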

Compound 4, half-maximal inhibitory concentration: 18400 nM
For compound 4 the middle estimate is 1.5-fold (0.19 log units) below the measured one; low and high end bracket the measured number.
By their numbers in this assay, from the lowest: compounds 2, 3, 1 and 4 (each within the scatter of the next, the first and the last beyond it).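

In this assay, replacing 4-chlorophenyl with 3-nitrophenyl on the aromatic nitrogen gives a 1.2-fold higher number from compound 3 to compound 4 (0.09 log units; within the scatter), so exchanging one substituted phenyl for the other, with 9 heavy atoms in place of 7 and 2 hydrogen-bond acceptors in place of 0, produces no readable change at this position. Compared with the plain phenyl group, the nitro group gives a 2.4-fold higher number from compound 2 to compound 4 (0.37 log units; beyond the scatter), the first step at this position to pass the scatter, although only modestly, and it shows that a group added to this phenyl ring can shift the number measurably. No measured evidence accompanies either step to explain it.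

Because 4-chlorophenyl and 3-nitrophenyl differ both in which group the ring carries and in where that group sits, the compounds shown cannot separate these two features. Going by these compounds, it also remains open whether an amine or a carboxylic acid in place of the nitro group on this phenyl ring would leave the number within the scatter of compound 2 or move it beyond, and in which direction.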